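This account rests on a few compounds, and the source may have more. Where it says the series, first, only, none or still open, it means among the compounds named here.

Measured so far in a functional assay on A549 cells (Homo sapiens) for inhibition, read by sulforhodamine B assay, tested at 100 uM; on this read-out higher numbers stand for more inhibition of growth at the one concentration tested and lower numbers for less inhibition of growth:
compound 1 `COc1cc(C2CC(c3ccccc3)=NN2C(C)=O)ccc1OCc1cn(Cc2ccc([N+](=O)[O-])cc2)nn1` — 11%
compound 2 `COc1ccc(C2CC(c3ccc(OCc4cn(Cc5ccc([N+](=O)[O-])cc5)nn4)cc3)=NN2C(C)=O)cc1OC` — 36%

Among the measured compounds shown here, compound 1 stands lowest of the two numbers; compound 2 lies a distance above it that is beyond the scatter, but no single-point step connects these two structures, so their pair says only what the two values show. From compound 1 the step to compound 3 `COc1cc(C2CC(c3ccc(Cl)cc3)=NN2C(C)=O)ccc1OCc1cn(Cc2ccc([N+](=O)[O-])cc2)nn1` is a change of one atom: chloro in place of hydrogen on an aromatic carbon, para to a large group. For the measured compounds named here, no measured pair in this assay contains such a change, so there is nothing here to size it from. With one heavy atom entering and nothing else moved, a step of about the scatter, in either direction, is the working expectation in this assay. Compound 3 is therefore expected near 18%, within 3% to 40%, which is an expected step of a number 7 percentage points higher from compound 1 to compound 3 (within the scatter).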

Compound 3, percent growth inhibition at one concentration: 0%
For compound 3 the middle estimate is 18 percentage points above the measured one; the whole stated range lies above it.
By their numbers in this assay, from the lowest: compound 3; then compound 1; then compound 2.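

Phenyl to 4-chlorophenyl gives the first sized step at this position: in this assay, chloro in place of hydrogen on an aromatic carbon, para to a large group, reads a number 11 percentage points lower from compound 1 to compound 3 (beyond the scatter). The position is therefore not silent to a single heavy atom, and on the core of compound 1 this change goes toward less inhibition of growth, with compound 3 at 0% in the same read-out. No measured information at hand accounts for the direction of this step.

Going by these compounds, a single substituent gives only one direction, so it remains open whether a dimethylamino group, a carboxylic acid or a methoxy group in the same place would move the read-out the same way. Also open, on these data alone, is whether fluoro, a smaller halogen, would follow chloro here.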